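The source may report more compounds than this note shows. Statements on the series, on what has been measured and on what is new or still open speak of the compounds shown alone.

Measured so far in a functional assay on DU-145 cells (Homo sapiens) for antiproliferative activity, read by propidium iodide staining, with a stated time of 96 h; a higher number here means a weaker inhibitor, a lower number a stronger inhibitor:
compound 1 `CC(O)(CSc1cccc(S(F)(F)(F)(F)F)c1)C(=O)Nc1ccc(C#N)c(C(F)(F)F)c1` gives 32700 nM; compound 2 `CC(O)(CSc1cccc(S(F)(F)(F)(F)F)c1)C(=O)Nc1ccc([N+](=O)[O-])c(C(F)(F)F)c1` gives 13900 nM; compound 3 `CC(O)(COc1cccc(S(F)(F)(F)(F)F)c1)C(=O)Nc1ccc(C#N)cc1C(F)(F)F` gives 16300 nM.

Between compound 1 and compound 2 the change is nitro in place of cyano on an aromatic carbon, and it gave a 2.4-fold lower number from compound 1 to compound 2 (0.37 log units; beyond the scatter). The difference between the core of compound 1 and the core of compound 3 is not broken down here. Compound 4 `CC(O)(COc1cccc(S(F)(F)(F)(F)F)c1)C(=O)Nc1ccc([N+](=O)[O-])cc1C(F)(F)F` has not yet been measured in this assay. It differs from compound 3 by nitro in place of cyano on an aromatic carbon. This is the same kind of change as that from compound 1 to compound 2, though not the same: there the nitro sits ortho to a trifluoromethyl group, here meta to a trifluoromethyl group. The step to compound 4 is expected to be a 2.2-fold lower number from compound 3 to compound 4 (0.34 log units; beyond the scatter), resting on the one shown step a 2.4-fold lower number from compound 1 to compound 2 (0.37 log units; beyond the scatter) and on the value of compound 3, 16300 nM. Compound 4 is therefore estimated at 7500 nM, between 3000 nM and 18000 nM.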

Compound 4, half-maximal inhibitory concentration: 18000 nM
Compound 4: the middle estimate sits 2.4-fold (0.38 log units) below what was measured; the range from low to high includes it.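

Carried to the core of compound 3 in this assay, nitro in place of cyano on an aromatic carbon gave a 1.1-fold higher number from compound 3 to compound 4 (0.04 log units; within the scatter). Set beside the step on the core of compound 1, the result does not differ by more than the scatter allows: the same change on two cores in this assay, a 2.4-fold lower number (0.37 log units; beyond the scatter) from compound 1 to compound 2 and a 1.1-fold higher number (0.04 log units; within the scatter) from compound 3 to compound 4, 2.6-fold (0.41 log units) apart, within the scatter of two such steps. This shows that the lower number seen on the first core did not clearly reappear on the second, but it does not show that the two cores respond differently, and two pairs cannot establish a rule for the series.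

The compounds shown leave open whether either step would hold on a third core. They also leave open how an amine or a carboxylic acid in place of the nitro or cyano group would compare.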